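The source may hold more compounds than are shown below. What is called first, only, known or untested is meant among the compounds shown, and "the series" means these compounds.

Working notes on the series.

Three compounds have numbers in a functional assay on DU-145 cells (Homo sapiens) for cytotoxicity, read by MTT assay, with a stated time of 48 h; a lower number here means a stronger inhibitor, a higher number a weaker inhibitor. Compound 1 `COc1ccc(-c2cc(C(=O)Nc3nc4ccc(F)cc4s3)nc3cc(-c4ccccc4)nn23)cc1OC` gives 18600 nM in this assay, compound 2 `COc1cc(-c2cc(C(=O)Nc3nc4ccc(F)cc4s3)nc3cc(-c4ccccc4)nn23)cc(OC)c1OC` gives 25700 nM, and compound 3 `COc1ccc(-c2cc(C(=O)Nc3nc4ccc(OC)cc4s3)nc3cc(-c4ccccc4)nn23)cc1` gives 7580 nM. Going by the values given here, the one counted change among the measured compounds is hydrogen in place of methoxy on an aromatic carbon, which made a 1.4-fold lower number from compound 2 to compound 1 (0.14 log units; within the scatter). How the core of compound 3 differs from that of compound 2 is not broken down here; the two values alone show compound 3 at the lower number.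

Compound 4 `COc1ccc(-c2cc(C(=O)Nc3nc4ccccc4s3)nc3cc(-c4ccccc4)nn23)cc1` is not yet measured. From compound 3 it differs by hydrogen in place of methoxy on an aromatic carbon. This is the same kind of change as that from compound 2 to compound 1, not the same: there the place was ortho to a methoxy group, meta to a large group and meta to a methoxy group on a single ring, whereas here it is on a ring that is part of a fused or bridged system of two rings, meta and para to a fused ring. Among the compounds with values here, with only one earlier step of this kind and a different place, the expectation stays close to compound 3, and the step from compound 3 to compound 4 is estimated at a 1.2-fold higher number from compound 3 to compound 4 (0.07 log units; within the scatter) in this assay. Compound 4 is thus expected to give about 9000 nM in this assay, between 3500 nM and 25000 nM.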

Compound 4, half-maximal inhibitory concentration: 2950 nM
For compound 4 the middle estimate is 3.1-fold (0.48 log units) above the measured one; measured number below the stated range.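

On the core of compound 3, hydrogen in place of methoxy on an aromatic carbon, the change from 6-methoxy-1,3-benzothiazol-2-yl to 1,3-benzothiazol-2-yl, gives a 2.6-fold lower number from compound 3 to compound 4 (0.41 log units; beyond the scatter) in this assay. Set beside the earlier step, this one cannot be told apart from it: the same change on two cores in this assay, a 1.4-fold lower number (0.14 log units; within the scatter) from compound 2 to compound 1 and a 2.6-fold lower number (0.41 log units; beyond the scatter) from compound 3 to compound 4, 1.9-fold (0.27 log units) apart, within the scatter of two such steps. Going by these compounds alone, this shows no difference in how the change acts on the two cores, but it does not show that the change carries over with a fixed size, since there are only two pairs, the change sits at a different place in each, and only the step to compound 4 lies beyond the scatter.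

Still open, from the compounds shown here alone, is how an amine, a carboxylic acid or a longer chain such as ethoxy would read in place of the methoxy of the 6-methoxy-1,3-benzothiazol-2-yl group. Also open, going by these compounds, is whether the same change at a third place on the shared core would give a step like either of these two.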